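Compound 3: Methoxy in Place of Fluoro

The source may report more compounds than this note shows. Statements on the series, on what has been measured and on what is new or still open speak of the compounds shown alone.

In an ADME assay on HepG2 cells (Homo sapiens) for cytotoxicity, read by MTT assay (a higher number here means a weaker inhibitor, a lower number a stronger inhibitor), compound 1 (`Fc1ccc(-c2nc(C(Cl)(Cl)Cl)nc3ccccc23)cc1`) gives > 125000 nM, which is a limit of the assay and not a number. Compound 2 (`FC(F)(F)c1cccc(-c2nc(C(Cl)(Cl)Cl)nc3ccccc23)c1`) gives > 125000 nM, likewise a limit. Compound 3 (`COc1ccc(-c2nc(C(Cl)(Cl)Cl)nc3ccccc23)cc1`) has methoxy in place of fluoro on an aromatic carbon, para to a large group: methoxy in place of fluoro on an aromatic carbon. Among the compounds with values here, no measured step is available, so the expectation in this assay rests on the limit of > 125000 nM in this assay, at which 2 of the 2 values shown sit, and is for no change beyond the scatter. The estimated change is an at least 1.1-fold lower number from compound 1 to compound 3 (0.05 log units; that floor lies within the scatter). For compound 3, the expected value is 110000 nM, with an estimated range of 45000 nM to 200000 nM.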

Compound 3, half-maximal inhibitory concentration: 125000 nM
For compound 3 the middle estimate is 1.1-fold (0.06 log units) below the measured one, within the range that was stated.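

In this assay, within the data shown here, compound 3 gives 125000 nM, the only value shown that is a number and not a limit. Methoxy in place of fluoro, on an aromatic carbon para to a large group, therefore gives a readable value at this position. The step for this change is a number no higher from compound 1 to compound 3 (the limit leaves the size open). The size of this change cannot be read because compound 1 carries only a limit: the limit of > 125000 nM in this assay, at which 2 of the 3 values shown sit.

The compounds shown leave open whether an amine, a carboxylic acid or a longer chain at this position would give a clearly lower number. They also leave open whether any change to the shared core would do so.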